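Dropping a hydroxyl from a terpenoid side chain

The source may hold more compounds than are shown below. What is called first, only, known or untested is meant among the compounds shown, and "the series" means these compounds.

Compound 1, with structure `COC1=C(OC)[C@H](O)[C@H](C/C=C(\C)CC/C=C(\C)C[C@H](O)/C=C(\C)CO)[C@@H](C)C1=O`, was tested in a functional assay on PC-3 cells (Homo sapiens) for inhibition, read by sulforhodamine B assay, with a stated time of 48 h; a higher number here means a weaker inhibitor of growth, a lower number a stronger inhibitor of growth. In this assay compound 1 gives > 30000 nM, which is a limit of the assay rather than a measured number. Compound 2, with structure `COC1=C[C@H](O)[C@H](C/C=C(\C)CC/C=C(\C)C[C@H](O)/C=C(\C)CO)[C@@H](C)C1=O`, differs from compound 1 by a hydrogen in place of methoxy on a double-bonded ring carbon. In this assay compound 2 gives > 30000 nM, again a limit of the assay and not a number. The step that the two limits leave unreadable from compound 1 to compound 2 cannot be read; both of its ends rest on (the limit of > 30000 nM in this assay, at which 2 of the 2 values shown sit).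

Compound 3, with structure `COC1=C(OC)[C@H](O)[C@H](C/C=C(\C)CC/C=C(\C)C[C@H](O)C=C(C)C)[C@@H](C)C1=O`, has not yet been measured. It differs from compound 1 as follows: hydrogen in place of hydroxy on a saturated chain carbon bound to a double-bonded chain carbon. Among the measured compounds shown here, no measured step touches this part of the molecule, and the single step that is known is unreadable, so nothing sets a direction or a size for the change. Compound 1 stands at the limit, and compound 3 is expected to stay there. The step of a number no higher from compound 1 to compound 3 (the limit leaves the size open) is estimated to be essentially flat. Compound 3 is therefore expected to give about 30000 nM in this assay, within a range from 10000 nM to 100000 nM.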

Compound 3, concentration for 50% growth inhibition: > 30000 nM
Compound 3 gave a limit, no number; the forecaster's own chance of this, stated with the estimate: 80%; the middle value lies on the limit itself.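

Compound 1 and compound 3 both rest on a limit of the assay rather than a number, so no new step can be read between them: the limit of > 30000 nM in this assay, at which 3 of the 3 values shown sit.

The compounds shown leave open whether swapping the hydroxy for hydrogen on the side chain changes growth inhibition at all, since none of them gives a measured value to compare.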